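Swapping the Furan on the Shared Core for a Pyrazole

The compounds below may be only part of what the source reports. "The series", "measured", "known", "first", "only" and "open" are said of these compounds alone.

Of the compounds shown here, three sharing one core have been measured in a functional assay on MV4-11 cells (Homo sapiens) for inhibition, read by resazurin assay, with a stated time of 72 h; on this read-out higher numbers stand for weaker inhibition of growth and lower numbers for stronger inhibition of growth. Compound 1 `Cc1ccc(-c2cncc(Cl)c2N2CCC3(CCNC3=O)CC2)o1` gives 4950 nM in this assay, the lowest of the three numbers. Compound 3 `Cn1cc(-c2cncc(Cl)c2N2CCC3(CCNC3=O)CC2)cn1` gives 5530 nM, which lies within the scatter of compound 1. Compound 2 `O=Cc1sccc1-c1cncc(Cl)c1N1CCC2(CCNC2=O)CC1` gives 28700 nM, the furthest from compound 1.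

Two steps describe these differences: a 5.8-fold higher number from compound 1 to compound 2 (0.76 log units; beyond the scatter), and a 1.1-fold higher number from compound 1 to compound 3 (0.05 log units; within the scatter).

Compound 4 `O=C1NCCC12CCN(c1c(Cl)cncc1-c1cnn(C(F)F)c1)CC2` has not yet been measured. It differs from compound 1 as follows: 1-(difluoromethyl)-1H-pyrazol-4-yl in place of 5-methylfuran-2-yl on an aromatic carbon. Within the data shown here, the step that bears on this change is the one from compound 1 to compound 3, in which a 1-methyl-1H-pyrazol-4-yl entered in place of the same 5-methylfuran-2-yl, and that step stayed within the scatter. A closely related group enters here, so a step within the scatter is expected in this assay, in no clear direction. The expected step is a 1.1-fold higher number from compound 1 to compound 4 (0.05 log units; within the scatter). Compound 4 is estimated at 5500 nM, with a range from 2500 nM to 12000 nM.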

Compound 4, concentration for 50% growth inhibition: 6140 nM
Compound 4: middle estimate off by 1.1-fold (0.05 log units), on the low side; the range from low to high includes it.
By their numbers in this assay, from the lowest: compounds 1, 3 and 4 (each within the scatter of the next); then compound 2.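

In this assay, difluoromethyl in place of methyl on the aromatic nitrogen gives a 1.1-fold higher number from compound 3 to compound 4 (0.05 log units; within the scatter), so the two fluorine atoms leave the read-out within the scatter. Among these compounds, with a 1.2-fold higher number from compound 1 to compound 4 (0.09 log units; within the scatter), a second pyrazole also stays within the scatter of the 5-methylfuran-2-yl group, while a 4.7-fold lower number from compound 2 to compound 4 (0.67 log units; beyond the scatter) leaves 2-formylthiophen-3-yl as the one group here that stands apart from the others. Nothing available explains why these groups read so alike.

Every group shown at this position is a five-membered aromatic ring, so the effect of a simple amine or a carboxylic acid there remains open. Also open, from the compounds shown here alone, is whether a longer chain on the pyrazole nitrogen would take the number beyond the scatter of compound 4.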